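The source may hold more compounds than are shown below. What is called first, only, known or untested is meant among the compounds shown, and "the series" means these compounds.

Measured in a functional assay on the whole organism for antagonist activity, with Mus musculus as the target; a lower number here means that less compound is needed, a higher number that more compound is needed for the effect:
compound 1 `COC(=O)N(C)CC#CCN1CCCC1`: > 10 mg/kg (a limit)
compound 2 `COC(=O)N(C)CC#CCn1ccnc1`: > 100 mg/kg (a limit)
compound 3 `COC(=O)N(C)CC#CCn1cncc1C`: 3 mg/kg

Compound 2 has no number. Compound 2 is known only through its limit of > 100 mg/kg.

Compound 4 `CN(C)C(=O)N(C)CC#CCn1ccnc1` has dimethylamino in place of methoxy on a carbonyl carbon, the same difference read as methoxycarbonyl to dimethylcarbamoyl: dimethylamino in place of methoxy on a carbonyl carbon.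

Two measured steps involve compound 2: a step that the two limits leave unreadable from compound 1 to compound 2, and an at least 33-fold lower number from compound 2 to compound 3 (1.52 log units; beyond the scatter). The first offers no size to carry over. The second is large, but it is methyl in place of hydrogen on an aromatic carbon and leaves the carbonyl carbon untouched. Going by the values given here, no measured step therefore bears directly on this change, although compound 3 shows that a single change can move the number far from compound 2.

With no evidence for a direction, no shift beyond the scatter is expected in this assay, and another limit is a likely result. The expected step is a number no higher from compound 2 to compound 4 (the limit leaves the size open). For compound 4 the estimated value is 100 mg/kg, with an expected range of 20 mg/kg to 300 mg/kg.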

Compound 4, dose for half-maximal effect: 11.8 mg/kg
The estimate for compound 4 lay 8.5-fold (0.93 log units) above the measured number; the measured number lies below the stated range.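

In this assay, the carbonyl carbon proves to be a position where a single change matters: dimethylamino in place of methoxy gives an at least 8.4-fold lower number from compound 2 to compound 4 (0.92 log units; beyond the scatter). Going by these compounds alone, earlier, the only readable step involving compound 2 was methyl in place of hydrogen on an aromatic carbon, so this is a second, separate position at which one change yields a measured number. The upper end of the step's size stays open because compound 2 is known only through a limit: the limit of > 100 mg/kg in this assay, at which 1 of the 4 values shown sits.

As far as these compounds go, whether methyl on the aromatic carbon and dimethylamino on the carbonyl carbon together would lower the number further remains open. Also open, from the compounds shown here alone, is how other groups on the carbonyl carbon, such as ethoxy or diethylamino, would compare with dimethylamino.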